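Swapping the bicyclic arm of a weak antiproliferative lead

A few compounds are considered here, and "the series" means these few. Any claim that something is new, unique, unknown or untested is made for them only; others in the source may bear on it.

Compound 1 `O=C1NC(O)(CCn2cnc3ccnc(Cl)c32)C(OCc2ccccc2)=C1OCc1ccccc1`: "not determined" (no result reported) in a functional assay on L1210/0 cells (Mus musculus) for antiproliferative activity, read by MTT assay, with a stated time of 72 h; a higher number here means a weaker inhibitor, a lower number a stronger inhibitor
Compound 2 `O=C1NC(O)(CCn2cnc3cncc(Br)c32)C(OCc2ccccc2)=C1OCc1ccccc1`: 50000 nM

Only compound 2 carries a number in this assay, and that number, 50000 nM for compound 2, marks it as a weak inhibitor. Compound 1 shares the core of compound 2 but was not assigned a value, so nothing can be said about how the two compare.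

Compound 3 `O=C1NC(O)(CCn2cnc3cc[nH]c3c2=O)C(OCc2ccccc2)=C1OCc1ccccc1` keeps that core and differs from compound 2 in a single region: a group of 10 heavy atoms (6 carbon, 3 nitrogen, 1 oxygen; one five-membered aromatic ring with 1 hetero atom, one six-membered aromatic ring with 2 hetero atoms) in place of a group of 10 heavy atoms (6 carbon, 3 nitrogen, 1 bromine; one five-membered aromatic ring with 2 hetero atoms, one six-membered aromatic ring with 1 hetero atom), on a saturated chain carbon, two bonds along the chain from a saturated ring carbon. In plain words, a group of 10 heavy atoms (6 carbon, 3 nitrogen, 1 oxygen; one five-membered aromatic ring with 1 hetero atom, one six-membered aromatic ring with 2 hetero atoms) takes the place of a group of 10 heavy atoms (6 carbon, 3 nitrogen, 1 bromine; one five-membered aromatic ring with 2 hetero atoms, one six-membered aromatic ring with 1 hetero atom), on a saturated chain carbon, two bonds along the chain from a saturated ring carbon.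

Going by the values given here, no pair of measured compounds shows what such a change does here, so the expected step of no change at the digits printed from compound 2 to compound 3 (within the scatter) is set at none beyond the scatter. Compound 3 is therefore estimated at 50000 nM, within 15000 nM to 160000 nM.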

Compound 3, half-maximal inhibitory concentration: 107000 nM
Compound 3: the middle estimate sits 2.1-fold (0.33 log units) below what was measured, and the stated range covers the measured number.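

In this assay, going by these compounds alone, the exchange on the saturated chain carbon, two bonds along the chain from a saturated ring carbon, gives a 2.1-fold higher number from compound 2 to compound 3 (0.33 log units; beyond the scatter), a modest step beyond the scatter and the first reading of any change at this position. It shows that the arm at this place is not indifferent to replacement, although the move is toward weaker inhibition and so offers no gain over the weak starting point. The exchange alters several things at once, replacing the bromine with an oxygen, moving a hetero atom between the five-membered and six-membered aromatic rings, and adding a double bond outside aromatic rings and a hydrogen-bond donor, and no measurement shown here says which of these accounts for the step.

Going by these compounds, it remains open whether any change at this position can lower the number rather than raise it, as might be tested with a simple amine or a carboxylic acid in place of the two-ring group, or with a longer chain carrying that group. Also open, on these data alone, is how far each part of the exchange counts on its own, such as the bromine taken alone with the rest of the group held constant.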